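The source may hold more compounds than are shown below. What is called first, only, known or untested is meant among the compounds shown, and "the series" means these compounds.

Measured in an in vitro ADME assay on microsomes from liver (Homo sapiens) for metabolic stability, tested at 1 uM; a higher number here means faster removal of the compound, a lower number slower removal:
- compound 1 `Cc1cc(/C=C/C#N)cc(C)c1Oc1cc(Nc2ccc(C#N)cc2)c(N)cc1C(N)=O`: 200 mL.min-1.g-1
- compound 2 `COC(=O)c1cc(N)c(Nc2ccc(C#N)cc2)cc1Oc1c(C)cc(CCC#N)cc1C`: 40 mL.min-1.g-1

Of these two, compound 2 stands lowest at 40 mL.min-1.g-1, and the value of compound 1, 200 mL.min-1.g-1, lies higher, beyond the scatter. Compound 3 `COC(=O)c1cc(N)c(Nc2ccc(C#N)cc2)cc1Oc1c(C)cc(/C=C/C#N)cc1C` departs from compound 2 in one place, with 2-cyanoethenyl in place of 2-cyanoethyl on an aromatic carbon. Within the data shown here, no measured step isolates this change, as compound 1 and compound 2 differ in more than one place. Among the measured compounds shown here, the only guide is that the 2-cyanoethenyl group also stands on compound 1, at 200 mL.min-1.g-1, so a modest rise in this assay is expected, within the scatter or only just beyond it. The estimated step is a 1.8-fold higher number from compound 2 to compound 3 (0.24 log units; within the scatter). For compound 3 the expected value is 70 mL.min-1.g-1, with an estimated range from 30 mL.min-1.g-1 to 170 mL.min-1.g-1.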

Compound 3, intrinsic clearance in microsomes: 20 mL.min-1.g-1
The estimate for compound 3 lay 3.5-fold (0.54 log units) above the measured number; measured number below the stated range.
By their numbers in this assay, from the lowest: compounds 3 and 2 (each within the scatter of the next); then compound 1.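

In this assay, putting 2-cyanoethenyl in place of 2-cyanoethyl on this aromatic carbon gives a 2.0-fold lower number from compound 2 to compound 3 (0.30 log units; within the scatter), so the double bond in this chain leaves no difference that can be told from the scatter. Among these compounds, the change of amino to methoxy on the carbonyl carbon, with 2-cyanoethenyl kept in place, gives a 10-fold lower number from compound 1 to compound 3 (1.00 log units; beyond the scatter); this is the first comparison to isolate that carbonyl position, and it shows that 2-cyanoethenyl does not by itself go with a high number. Nothing shown accounts for either step.

On these data alone, whether the carbonyl step would be of the same size with 2-cyanoethyl on the ring remains open. So does where an ethoxy group, a methylamino group or a carboxylic acid at the carbonyl carbon, or a longer nitrile chain on the aromatic carbon, would fall.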